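Ethoxycarbonyl in place of hydroxymethyl: notes on compound 4

The source may hold more compounds than are shown below. What is called first, only, known or untested is meant among the compounds shown, and "the series" means these compounds.

Measured so far in a functional assay on A549 cells (Homo sapiens) for cytotoxicity, read by MTT assay, with a stated time of 48 h; a lower number here means a stronger inhibitor, a higher number a weaker inhibitor
- compound 1 `CCOC(=O)C1(C(=O)Nc2ccccc2Cl)CC1c1cc(OC)c(OC)c(OC)c1` gives 18000 nM; 18500 nM (2 entries)
- compound 2 `CCOC(=O)[C@@]1(C(=O)Nc2ccccc2Cl)C[C@@H]1c1cc(OC)c(OC)c(OC)c1` gives 29000 nM
- compound 3 `COc1cc([C@H]2C[C@]2(CO)C(=O)Nc2ccccc2Cl)cc(OC)c1OC` gives 36700 nM

Going by the values given here, the entries for compound 1 agree closely the several entries of compound 1 in this assay, 18000 nM; 18500 nM (2 entries) and configuration is defined in only one of compound 1 and compound 2 the fact that one of compounds 1 and 2 is drawn with a defined configuration and the other without, at the place where they differ at the place where they differ. Compound 3 stands at 36700 nM and lies within the scatter of compound 2 at 29000 nM in this series.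

Compound 4 `CCOC(=O)[C@]1(C(=O)Nc2ccccc2Cl)C[C@@H]1c1cc(OC)c(OC)c(OC)c1` has ethoxycarbonyl in place of hydroxymethyl on a saturated ring carbon and so carries the group found in compound 1 and compound 2. Among the compounds with values here, no measured step isolates this change. Only a small shift is expected in this assay because compound 2 at 29000 nM already bears ethoxycarbonyl and sits within the scatter of compound 3. The expected step of a 1.5-fold lower number from compound 3 to compound 4 (0.18 log units; within the scatter) is therefore small. For compound 4 the estimate is 24000 nM with an expected range from 11000 nM to 50000 nM in this assay.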

Compound 4, half-maximal inhibitory concentration: 50900 nM
Compound 4: middle estimate off by 2.1-fold (0.33 log units), on the low side, outside the stated range (above it).
By their numbers in this assay, from the lowest: compounds 2, 3 and 4 (each within the scatter of the next).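

In this assay, the exchange of hydroxymethyl for ethoxycarbonyl on a saturated ring carbon now has a measured step, a 1.4-fold higher number from compound 3 to compound 4 (0.14 log units; within the scatter), and that step lies within the scatter. Configuration at this carbon can also be read on its own, with a 1.8-fold higher number from compound 2 to compound 4 (0.24 log units; within the scatter), again within the scatter: the fact that compounds 2 and 4 differ only in the configuration as drawn. Across compounds 2, 3 and 4, neither the exchange of these two groups nor the configuration drawn at this carbon gives a step beyond the scatter in this assay.

As far as these compounds go, whether another group at this carbon, such as an amine or a carboxylic acid, would give a step beyond the scatter remains open. The other stereo element, drawn alike in compound 2 and compound 4, also remains unread.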